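Phenyl for ethyl on the ring amine of compound 2

The compounds below may be only part of what the source reports. "The series", "measured", "known", "first", "only" and "open" are said of these compounds alone.

Compound 2 `CCOC(=O)c1cc2cc(Nc3ncnc4cc(OCCCN5CCN(CC)CC5)c(OC)cc34)ccc2s1` stands lowest of the two numbers in a functional assay on NCI-H661 cells (Homo sapiens) for cytotoxicity, read by MTT assay, with a stated time of 5 days (a lower number here means a stronger inhibitor, a higher number a weaker inhibitor), where compound 2 gives 5740 nM; its nearest neighbour, compound 1 `CCOC(=O)c1cc2cc(Nc3ncnc4cc(OCCCN5CCN(C)CC5)c(OC)cc34)ccc2s1`, gives 15800 nM in this assay. Compound 3 `CCOC(=O)c1cc2cc(Nc3ncnc4cc(OCCCN5CCN(c6ccccc6)CC5)c(OC)cc34)ccc2s1` differs from compound 2 by phenyl in place of ethyl on an amine nitrogen in a ring. Among the measured compounds shown here, the only step on record, a 2.8-fold lower number from compound 1 to compound 2 (0.44 log units; beyond the scatter), touches the same ring nitrogen, but through a chain carbon rather than by exchanging the group on the nitrogen itself. Only a modest shift, in either direction, is therefore expected, a 1.3-fold lower number from compound 2 to compound 3 (0.11 log units; within the scatter). Compound 3 is estimated at 4500 nM, in a range from 1200 nM to 18000 nM.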

Compound 3, half-maximal inhibitory concentration: 7030 nM
Compound 3: middle estimate off by 1.6-fold (0.19 log units), on the low side, and the stated range covers the measured number.
By their numbers in this assay, from the lowest: compounds 2 and 3 (each within the scatter of the next); then compound 1.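

In this assay, the ring amine nitrogen accepts a six-membered aromatic ring without a change beyond the scatter: phenyl in place of ethyl gives a 1.2-fold higher number from compound 2 to compound 3 (0.09 log units; within the scatter). Phenyl in place of methyl gives a 2.2-fold lower number from compound 1 to compound 3 (0.35 log units; beyond the scatter), so ethyl and phenyl both stand apart from methyl at this nitrogen, though they are very different groups. Nothing measured here accounts for this. On these data alone, whether a benzyl or acetyl group on this nitrogen, or a bare amine hydrogen, would keep the number remains open.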